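The source may hold more compounds than are shown below. What is called first, only, known or untested is meant among the compounds shown, and "the series" means these compounds.

Measured so far in an assay for binding affinity to 5-hydroxytryptamine receptor 1F (Homo sapiens), read by radioligand binding; a lower number here means a stronger inhibitor, a higher number a weaker inhibitor:
- compound 1 `CCCCCC(=O)Nc1ccc2[nH]cc(C3CCN(C)CC3)c2n1`: 13 nM
- compound 2 `CCCCC(=O)Nc1ccc2[nH]cc(C3CCN(C)CC3)c2n1`: 14 nM
- compound 3 `CCN1CCC(c2c[nH]c3ccc(NC(=O)c4ccc(F)cc4)nc23)CC1`: 170 nM

Compound 1 and compound 2 differ in one place, (methyl in place of hydrogen on a saturated chain carbon, four bonds along the chain from a carbonyl carbon), and the step of a 1.1-fold lower number from compound 2 to compound 1 (0.03 log units; within the scatter). Compound 3 carries a different amide and a different core; the difference between the cores of compound 2 and compound 3 is not broken down here. Compound 3 gives the highest number of the three, a gap to compound 2 and compound 1 that lies beyond the scatter.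

Compound 4 `CCCN1CCC(c2c[nH]c3ccc(NC(=O)c4ccc(F)cc4)nc23)CC1` is not yet measured. It is related to compound 3 by methyl in place of hydrogen on a saturated chain carbon, two bonds along the chain from an amine nitrogen in a ring. This is the same kind of change as that from compound 2 to compound 1, but not the same: there the added carbon sits four bonds along the chain from a carbonyl carbon, here two bonds along the chain from an amine nitrogen in a ring. For the measured compounds named here, the only guide is the step of a 1.1-fold lower number from compound 2 to compound 1 (0.03 log units; within the scatter), which is within the scatter, so a comparable step a 1.1-fold lower number from compound 3 to compound 4 (0.03 log units; within the scatter) is expected for compound 4. Compound 4 is therefore estimated at 160 nM, with a range from 70 nM to 360 nM.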

Compound 4, inhibition constant: 18 nM
Compound 4: the middle estimate sits 8.9-fold (0.95 log units) above what was measured, outside the stated range (below it).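

In this assay, the change from 1-ethylpiperidin-4-yl to 1-propylpiperidin-4-yl gives a 9.4-fold lower number from compound 3 to compound 4 (0.98 log units; beyond the scatter), so adding one methyl to a saturated chain has no fixed size of effect in this series. The step seen with the earlier pair does not predict the new one: the same change on two cores in this assay, a 1.1-fold lower number (0.03 log units; within the scatter) from compound 2 to compound 1 and a 9.4-fold lower number (0.98 log units; beyond the scatter) from compound 3 to compound 4, 8.8-fold (0.94 log units) apart, beyond the scatter of two such steps The comparison does not show whether place or core accounts for the gap, since the added carbon sits four bonds along the chain from a carbonyl carbon in one step and two bonds along the chain from an amine nitrogen in a ring in the other, and each step rests on a single pair.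

Open, as far as these compounds go, is whether a longer chain on the ring nitrogen, such as butyl, continues the direction of the step to compound 4. Also open, from the compounds shown here alone, is whether the same ethyl to propyl change has a similar effect alongside the chain amide of compound 1 rather than the amide of compound 4.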